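Halogenated anilines on a shared core in a cell growth assay

The compounds below may be only part of what the source reports. "The series", "measured", "known", "first", "only" and "open" are said of these compounds alone.

Three compounds that share one core and differ only in the aryl group on the ring nitrogen have been tested in a functional assay on PC-3 cells (Homo sapiens) for inhibition, read by MTT assay, with a stated time of 72 h; on this read-out higher numbers stand for weaker inhibition and lower numbers for stronger inhibition. Compound 1 `C=CC(=O)Nc1cccc(NC(=O)CSc2nc(Nc3cccc(Cl)c3)c3ccccc3n2)c1` gives 12300 nM, compound 2 `C=CC(=O)Nc1cccc(NC(=O)CSc2nc(Nc3ccc(Cl)cc3)c3ccccc3n2)c1` gives 10800 nM, and compound 3 `C=CC(=O)Nc1cccc(NC(=O)CSc2nc(Nc3ccc(Br)cc3)c3ccccc3n2)c1` gives 12400 nM. The steps among them, a 1.1-fold lower number from compound 1 to compound 2 (0.06 log units; within the scatter), a 1.0-fold higher number from compound 1 to compound 3 (0.00 log units; within the scatter) and a 1.1-fold higher number from compound 2 to compound 3 (0.06 log units; within the scatter), all lie within the scatter, so compound 3 stands level with the other two on the numbers shown. Compound 4 `C=CC(=O)Nc1cccc(NC(=O)CSc2nc(Nc3ccc(Cl)c(Cl)c3)c3ccccc3n2)c1` carries 3,4-dichlorophenyl in place of 4-bromophenyl on a nitrogen on an aromatic ring. Within the data shown here, no measured step tests the entry of a second chloro group, but the three steps that do exist show that swapping chloro for bromo and moving the halogen around the ring left this assay unchanged. From this it is expected that the step of a 1.1-fold lower number from compound 3 to compound 4 (0.05 log units; within the scatter) will stay within the scatter. Compound 4 is therefore estimated at 11000 nM, with a range from 5000 nM to 25000 nM.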

Compound 4, half-maximal inhibitory concentration: 27600 nM
Estimate against measurement, compound 4: 2.5-fold (0.40 log units) below; measured number above the stated range.
By their numbers in this assay, from the lowest: compounds 2, 1 and 3 (each within the scatter of the next); then compound 4.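

In this assay, the aryl group on this nitrogen responded to a second halogen, although it had not responded to the kind or the place of a single one: chloro in place of hydrogen gives a 2.6-fold higher number from compound 2 to compound 4 (0.41 log units; beyond the scatter) and also a 2.2-fold higher number from compound 1 to compound 4 (0.35 log units; beyond the scatter) on the same ring. The exchange of 4-bromophenyl for 3,4-dichlorophenyl points the same way, with a 2.2-fold higher number from compound 3 to compound 4 (0.35 log units; beyond the scatter) towards weaker inhibition, so compound 4 alone stands apart from the three compounds with one halogen. Nothing available explains this change.

From the compounds shown here alone, whether only a second chloro does this remains open, since a bromo, methyl or methoxy group in its place would be needed to tell. Going by these compounds, it is also open whether a plain phenyl on this nitrogen would stand level with compound 1, compound 2 and compound 3.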